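Phenyl-to-methyl exchange on the saturated ring

The source may hold more compounds than are shown below. What is called first, only, known or untested is meant among the compounds shown, and "the series" means these compounds.

Compound 1 `COC(=O)C1C(=O)C=C(Nc2ccc(N3CCN(C)CC3)cc2)CC1c1ccccc1` and compound 2 `COC(=O)C1C(=O)C=C(Nc2cccc(N3CCN(C)CC3)c2)CC1c1ccccc1` share the same atoms joined differently; the difference between the two cores is not broken down here. In a physicochemical assay for lipophilicity (a lower number here means a more polar compound, a higher number a more lipophilic compound), compound 1 gives 4.02, and compound 2 gives 3.99, a pair within the scatter of each other. Compound 3 `COC(=O)C1C(=O)C=C(Nc2ccc(N3CCN(C)CC3)cc2)CC1C` gives 2.7 in this assay. The change from compound 1 to compound 3 is methyl in place of phenyl on a saturated ring carbon and produced a number 1.32 log units lower from compound 1 to compound 3 (beyond the scatter).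

Compound 4 `COC(=O)C1C(=O)C=C(Nc2cccc(N3CCN(C)CC3)c2)CC1C` has not been measured. Its relation to compound 2 is methyl in place of phenyl on a saturated ring carbon, the same change as from compound 1 to compound 3, and it occurs twice among these compounds. Because a number 1.32 log units lower from compound 1 to compound 3 (beyond the scatter) is the only step of this kind in hand, the expectation for compound 4 rests on it alone, applied to compound 2 as starting point; a drop of about the same size is expected, a number 1.32 log units lower from compound 2 to compound 4 (beyond the scatter). Compound 4 is accordingly estimated at 2.67 in this assay, with a range from 2.3 to 3.05 expected to hold most repeat measurements.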

Compound 4, partition coefficient: 2.67
Estimate against measurement, compound 4: no gap at the digits printed, and the stated range covers the measured number.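

In this assay methyl in place of phenyl on a saturated ring carbon gives a number 1.32 log units lower from compound 2 to compound 4 (beyond the scatter) against a number 1.32 log units lower from compound 1 to compound 3 (beyond the scatter) for the other pair, the same size at the digits printed, so the change carried from the core of compound 1 to the core of compound 2. This rests on two cores only, and with compound 1 and compound 2 starting within the scatter of each other, it shows nothing for a core with a clearly different starting value. No measurement here accounts for the size of the step, and the two pairs do not separate the departure of phenyl from the arrival of methyl.

Open, going by these compounds, is how the number moves between methyl and phenyl on that saturated ring carbon, for example with an ethyl group, a longer chain or an amine. Also open, on these data alone, is whether the step keeps its size when a carboxylic acid stands in place of the methoxycarbonyl group.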